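The source may report more compounds than this note shows. Statements on the series, on what has been measured and on what is new or still open speak of the compounds shown alone.

Measured in an assay on cells with melanin-concentrating hormone receptor 1 (Homo sapiens) as the target, read by radioligand binding; a lower number here means a stronger inhibitor, a higher number a weaker inhibitor:
- compound 1, `CCCCOc1cccc2ccc(N)nc12`, 789 nM
- compound 2, `Nc1ccc2cccc(OCCC3CC3)c2n1`, 492 nM
- compound 3, `CCC(CC)C(C)Oc1cccc2ccc(N)nc12`, 191 nM

Among these three, compound 3 gives the lowest number in this assay. Within the data shown here, compound 2 is the nearest to it, with a higher number that lies beyond the scatter, and compound 1 is furthest, with a still higher number; no single-point step is recorded between compound 3 and either of them, so only the values themselves can be compared.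

Compound 4, `CC(COC(C)(C)C)Oc1cccc2ccc(N)nc12`, differs from compound 3 in one place: (tert-butoxy)methyl in place of pentan-3-yl on a saturated chain carbon bound to an oxygen on an aromatic ring and a saturated chain carbon. Among the measured compounds shown here, the only measured step, a 1.6-fold lower number from compound 1 to compound 2 (0.21 log units; within the scatter), concerns a different part of the chain and was within the scatter. For the measured compounds named here, no measured step alters the group at this carbon, and none introduces an oxygen into the chain, so the recorded data give little guidance on the size or direction of the change. Given that the chain remains of similar size, compound 4 is expected to stay in the same general region as compound 3, with a modest shift toward a higher number allowed for; the step of a 2.1-fold higher number from compound 3 to compound 4 (0.32 log units; beyond the scatter) expresses this expectation. The estimate for compound 4 in this assay is 400 nM, with a range from 120 nM to 1300 nM.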

Compound 4, half-maximal inhibitory concentration: 306 nM
Estimate against measurement, compound 4: 1.3-fold (0.12 log units) above; low and high end bracket the measured number.
By their numbers in this assay, from the lowest: compounds 3, 4, 2 and 1 (each within the scatter of the next, the first and the last beyond it).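

In this assay the exchange of pentan-3-yl for (tert-butoxy)methyl, on a saturated chain carbon bound to an oxygen on an aromatic ring and a saturated chain carbon, gave a 1.6-fold higher number from compound 3 to compound 4 (0.20 log units; within the scatter) and so leaves compound 3 and compound 4 indistinguishable in this measurement. Among these compounds, this is the first measured change of the group at this carbon, and it shows that an all-carbon group of 5 heavy atoms and no hydrogen-bond acceptor can give way to a group of 6 heavy atoms, one of them oxygen, with 1 hydrogen-bond acceptor, without a change that can be separated from the scatter. No measurement shown here bears on why the two values stay this close.

The compounds shown leave open whether a smaller ether such as methoxymethyl, or a charged group such as an amine or a carboxylic acid, would be tolerated at this carbon in the same way. They also leave open whether a longer chain carrying the same tert-butoxy group would keep the number in this range.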